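Replacing 6-chloropyridin-3-yl with 2-fluorophenyl: working notes

This account rests on a few compounds, and the source may have more. Where it says the series, first, only, none or still open, it means among the compounds named here.

Measured in a functional assay on HepG2 cells (Homo sapiens) for cytotoxicity, read by MTT assay, with a stated time of 72 h; on this read-out higher numbers stand for weaker inhibition and lower numbers for stronger inhibition:
- compound 1 `Nc1ccccc1NC(=O)c1ccc(NC(=S)NCc2cccc(F)c2)cc1`: 2900 nM
- compound 2 `Nc1ccccc1NC(=O)c1ccc(NC(=S)NCc2ccc(Cl)nc2)cc1`: 19000 nM

Among the measured compounds shown here, compound 2, at 19000 nM, holds the higher of the two numbers, and its only neighbour is compound 1 at 2900 nM. The next change leads to compound 3 `Nc1ccccc1NC(=O)c1ccc(NC(=S)NCc2ccccc2F)cc1`: 2-fluorophenyl in place of 6-chloropyridin-3-yl on a saturated chain carbon bound to an amide-type nitrogen. In words, this puts 2-fluorophenyl in place of 6-chloropyridin-3-yl on a saturated chain carbon bound to an amide-type nitrogen.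

For the measured compounds named here, one measured step bears on this: a 6.6-fold higher number from compound 1 to compound 2 (0.82 log units; beyond the scatter), with 6-chloropyridin-3-yl in place of 3-fluorophenyl at that same place. That step is modest. Going by the values given here, compound 3 drops the same 6-chloropyridin-3-yl, but no measured compound carries 2-fluorophenyl, so the size of the return is uncertain. A move of similar size towards a lower number is expected in this assay. The estimate is a 5.8-fold lower number from compound 2 to compound 3 (0.76 log units; beyond the scatter). For compound 3 the expected value is 3300 nM, with an estimated range of 1200 nM to 8000 nM.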

Compound 3, half-maximal inhibitory concentration: 5400 nM
For compound 3 the middle estimate is 1.6-fold (0.21 log units) below the measured one, within the range that was stated.
By their numbers in this assay, from the lowest: compounds 1 and 3 (each within the scatter of the next); then compound 2.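

In this assay, a second fluorophenyl group also moves away from the number of compound 2, a 3.5-fold lower number from compound 2 to compound 3 (0.55 log units; beyond the scatter), so the higher number is not tied to the comparison with 3-fluorophenyl alone. Between the two fluorophenyl groups, a 1.9-fold higher number from compound 1 to compound 3 (0.27 log units; within the scatter), and this step does not separate 2-fluorophenyl from 3-fluorophenyl at this place on a saturated chain carbon bound to an amide-type nitrogen. No supporting measurement accompanies these values, and the gap between 6-chloropyridin-3-yl and the fluorophenyl groups stays unexplained.

The compounds shown do not tell whether the ring nitrogen or the chlorine of 6-chloropyridin-3-yl goes with the higher number. They also leave open how an unsubstituted benzyl, a longer chain, or a ring bearing an amine or a carboxylic acid would read at this place.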